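Methoxycarbonyl to ethoxycarbonyl on compound 2

The compounds below may be only part of what the source reports. "The series", "measured", "known", "first", "only" and "open" are said of these compounds alone.

In a functional assay on HL-60 cells (Homo sapiens) for cytotoxicity, read by MTT assay, with a stated time of 72 h (a higher number here means a weaker inhibitor, a lower number a stronger inhibitor), compound 1 (`CCOC(=O)c1sc2ccccc2c1Nc1cc(OC)c(OC)c(OC)c1`) gives 5490 nM and compound 2 (`COC(=O)c1sc2cc(C)ccc2c1Nc1cc(OC)c(OC)c(OC)c1`) gives 20.5 nM. Compound 2 therefore holds the lower of the two numbers, and its gap to compound 1 lies beyond the scatter. Compound 3 (`CCOC(=O)c1sc2cc(C)ccc2c1Nc1cc(OC)c(OC)c(OC)c1`) is compound 2 with methyl in place of hydrogen on a saturated chain carbon bound to an oxygen next to a carbonyl group, which turns methoxycarbonyl into ethoxycarbonyl. Going by the values given here, the measured compounds offer no step that differs in one place, so no direct precedent exists for this change. Compound 1 also carries ethoxycarbonyl and reads 5490 nM, which suggests a moderate rise in the number in this assay, beyond the scatter. The estimated change a 5.9-fold higher number from compound 2 to compound 3 (0.77 log units; beyond the scatter) is a weakening. For compound 3 the expected value is 120 nM, with an estimated range of 22 nM to 900 nM.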

Compound 3, half-maximal inhibitory concentration: 3.9 nM
For compound 3 the middle estimate is 31-fold (1.49 log units) above the measured one; the measured number lies below the stated range.
By their numbers in this assay, from the lowest: compound 3; then compound 2; then compound 1.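

In this assay the added methyl on a saturated chain carbon bound to an oxygen next to a carbonyl group brings a 5.3-fold lower number from compound 2 to compound 3 (0.72 log units; beyond the scatter) and so turns methoxycarbonyl to ethoxycarbonyl into a gain at this position. Compound 3 also separates the two changes that compound 1 left joined, as methyl on an aromatic carbon brings a 1400-fold lower number from compound 1 to compound 3 (3.15 log units; beyond the scatter) with ethoxycarbonyl held constant, so ethoxycarbonyl does not go with a high number once that methyl is present. No measured data bear on the reason for either step.

From the compounds shown here alone, whether the gain continues to propoxycarbonyl or butoxycarbonyl, or survives replacement of ethoxycarbonyl by a carboxylic acid or a primary amide, stays open. Also open, going by these compounds, is whether chloro or methoxy can stand in for the methyl on an aromatic carbon.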